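A nitrile on the distal ring of a cyclopropane amide series

The source may hold more compounds than are shown below. What is called first, only, known or untested is meant among the compounds shown, and "the series" means these compounds.

Three compounds sharing one amide core have been characterised in a functional assay for agonist activity at G protein-coupled receptor 88 (Homo sapiens), read by HTRF and cAMP accumulation; a lower number here means that less compound is needed, a higher number that more compound is needed for the effect. Compound 1 `COc1ccc(-c2ccc(N(C[C@@H](N)CC(C)C)C(=O)[C@@H]3C[C@H]3c3ccccc3)cc2)cc1` gives 330 nM. Compound 2 `CC(C)C[C@H](N)CN(C(=O)[C@@H]1C[C@H]1c1ccccc1)c1ccc(-c2cccc(F)c2)cc1` gives 2100 nM, and compound 3 `CC(C)C[C@H](N)CN(C(=O)[C@@H]1C[C@H]1c1ccccc1)c1ccc(-c2ccccc2F)cc1` gives 1600 nM. Compound 3 thus holds the second highest of the three numbers: its nearest neighbour is compound 2, from which it is separated only by a 1.3-fold lower number from compound 2 to compound 3 (0.12 log units; within the scatter), a gap within the scatter, while compound 1 lies furthest away, the step of a 4.8-fold higher number from compound 1 to compound 3 (0.69 log units; beyond the scatter) being beyond the scatter.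

The next compound, compound 4 `CC(C)C[C@H](N)CN(C(=O)[C@@H]1C[C@H]1c1ccccc1)c1ccc(-c2cccc(C#N)c2)cc1`, changes the distal aryl ring once more: 3-cyanophenyl in place of 2-fluorophenyl on an aromatic carbon. Two kinds of measured step bear on this change. Exchanging one fluorophenyl for another, a 1.3-fold lower number from compound 2 to compound 3 (0.12 log units; within the scatter), moved the number within the scatter. Replacing 4-methoxyphenyl by a fluorophenyl, a 6.4-fold higher number from compound 1 to compound 2 (0.80 log units; beyond the scatter) and a 4.8-fold higher number from compound 1 to compound 3 (0.69 log units; beyond the scatter), gave modest steps upward in both cases. Among the compounds with values here, a 3-cyanophenyl has not yet been tried, so the data give no direct precedent for a nitrile here; the closest analogue by ring pattern is compound 2 at 2100 nM. Compound 4 is therefore expected to stay near compound 3, with an estimated step of a 1.1-fold lower number from compound 3 to compound 4 (0.03 log units; within the scatter). The estimate for compound 4 is 1500 nM, with a range from 450 nM to 5000 nM.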

Compound 4, half-maximal effective concentration: 4500 nM
Estimate against measurement, compound 4: 3.0-fold (0.48 log units) below, and the stated range covers the measured number.
By their numbers in this assay, from the lowest: compound 1; then compounds 3 and 2 (each within the scatter of the next); then compound 4.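

In this assay, cyano in place of fluoro gives a 2.1-fold higher number from compound 2 to compound 4 (0.33 log units; beyond the scatter) and so shows that the identity of the group on this ring can move the number beyond the scatter, which the exchange between the two fluorophenyl rings did not show. Within the data shown here, compound 4 now has the highest number of the four, with a 2.8-fold higher number from compound 3 to compound 4 (0.45 log units; beyond the scatter) against the 2-fluorophenyl ring and a 14-fold higher number from compound 1 to compound 4 (1.13 log units; beyond the scatter) against the 4-methoxyphenyl ring, the latter being the only step in the set rated large, so neither fluorophenyl nor 3-cyanophenyl comes close to the 4-methoxyphenyl ring of compound 1. No measurement offered here accounts for the higher number that comes with the nitrile.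

As far as these compounds go, it stays open whether the low number of compound 1 belongs to the methoxy group itself or to its place on the ring, a question that a 3-methoxyphenyl or a 4-fluorophenyl ring would help to separate. Also open, from the compounds shown here alone, is how a longer chain such as ethoxy, an amine or a carboxylic acid on this ring would compare with these four compounds.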